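Replacing the ethyl ester of compound 2 with (furan-2-yl)methyl

This account rests on a few compounds, and the source may have more. Where it says the series, first, only, none or still open, it means among the compounds named here.

Measured in an assay on CHO cells for inhibition of metabotropic glutamate receptor 1 (Rattus norvegicus); a lower number here means a stronger inhibitor, a higher number a weaker inhibitor:
compound 1 `Cc1c(C(=O)OC(C)(C)C)c[nH]c1C(=O)OC(C)(C)C` gives 100 nM;
compound 2 `CCOC(=O)c1[nH]cc(C(=O)OC(C)(C)C)c1C` gives 340 nM;
compound 3 `CCN1CCC(OC(=O)c2[nH]cc(C(=O)OC(C)C(C)(C)C)c2C)C1` gives 260 nM.

Compound 2 carries the highest number of the three; compound 3 lies within the scatter of it, and only compound 1 stands beyond the scatter. Compound 4 `Cc1c(C(=O)OC(C)(C)C)c[nH]c1C(=O)OCc1ccco1` differs from compound 2 by furan-2-yl in place of methyl on a saturated chain carbon bound to an oxygen next to a carbonyl group. For the measured compounds named here, the one measured step at this ester oxygen is a 3.4-fold higher number from compound 1 to compound 2 (0.53 log units; beyond the scatter), tert-butyl giving way to ethyl with a modest rise. Compound 4 varies the same ester in another direction, for which nothing has been measured, so the step from compound 2 in this assay is expected to be small, if anything towards a lower number. Compound 4 is estimated at 220 nM, range 90 nM to 550 nM, an expected step of a 1.5-fold lower number from compound 2 to compound 4 (0.19 log units; within the scatter).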

Compound 4, half-maximal inhibitory concentration: 1200 nM
Beside the measured number, compound 4's estimate is 5.5-fold (0.74 log units) below it; the measured number lies above the stated range.
By their numbers in this assay, from the lowest: compound 1; then compounds 3 and 2 (each within the scatter of the next); then compound 4.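

In this assay, the ester group gains nothing from an aromatic ring on this saturated chain carbon: a 3.5-fold higher number from compound 2 to compound 4 (0.55 log units; beyond the scatter) shows furan-2-yl in place of methyl giving a weaker inhibitor. Against tert-butyl the change is larger, with a 12-fold higher number from compound 1 to compound 4 (1.08 log units; beyond the scatter), so the order among these three esters runs tert-butyl, ethyl, (furan-2-yl)methyl. Nothing at hand explains why the number rises.

Going by these compounds, it remains open whether the furan oxygen or the ring as such sets this rise, which a phenyl ring on the same carbon would separate. On these data alone, how a carboxylic acid in place of this ester would read also remains open.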